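The source may hold more compounds than are shown below. What is called first, only, known or untested is meant among the compounds shown, and "the series" means these compounds.

Measured so far in an assay on U2OS cells for activation of nuclear factor erythroid 2-related factor 2 (Homo sapiens), read by beta-arrestin recruitment, with a stated time of 6 h; a lower number here means that less compound is needed, a higher number that more compound is needed for the effect: compound 1 `O=S(=O)(/C=C/c1ccccn1)c1ccccc1Cl` gives 618 nM; compound 2 `O=S(=O)(/C=C/c1ncccc1F)c1ccccc1Cl` gives 122 nM; compound 3 `O=S(=O)(/C=C/c1ccccn1)c1cccc(Cl)c1` gives 1430 nM.

Compound 1 and compound 2 differ by one change, (fluoro in place of hydrogen on an aromatic carbon), and that change made a step of a 5.1-fold lower number from compound 1 to compound 2 (0.70 log units; beyond the scatter). Compound 3 has the same atoms as compound 1 joined differently; the difference between the two cores is not broken down here. Compound 3 shows the highest number of the three.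

Compound 4 `O=S(=O)(/C=C/c1ncccc1F)c1cccc(Cl)c1` is not yet measured. It stands to compound 3 as compound 2 stands to compound 1, by the same change, (fluoro in place of hydrogen on an aromatic carbon), at a place described in the same words.

Among the measured compounds shown here, only one earlier step for this change exists, so the expectation rests on compound 1 alone: because that step was a 5.1-fold lower number from compound 1 to compound 2 (0.70 log units; beyond the scatter), a step of about a 4.5-fold lower number from compound 3 to compound 4 (0.65 log units; beyond the scatter) is expected from compound 3 to compound 4 in this assay, with the core of compound 3 as the untested factor. For compound 4 the expected value is 320 nM, estimated within 120 nM to 900 nM.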

Compound 4, half-maximal effective concentration: 198 nM
Estimate against measurement, compound 4: 1.6-fold (0.21 log units) above, and the stated range covers the measured number.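

In this assay the fluoro change carried over to the second core, giving a 7.2-fold lower number from compound 3 to compound 4 (0.86 log units; beyond the scatter), and the two steps agree in size: the same change on two cores in this assay, a 5.1-fold lower number (0.70 log units; beyond the scatter) from compound 1 to compound 2 and a 7.2-fold lower number (0.86 log units; beyond the scatter) from compound 3 to compound 4, 1.4-fold (0.15 log units) apart, within the scatter of two such steps. On these two cores, which hold the same atoms joined differently, the size of the step shows no measurable dependence on the core. Two pairs in one assay do not show that the step would hold on any other core, and they do not explain why it arises.

Open, going by these compounds, is whether a methoxy group or an amine on the same aromatic carbon would give a step of similar size. Also open, on these data alone, is whether the step survives when a nitrile replaces the chloro group.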